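Swapping a charged group for nitro in the series

The source may report more compounds than this note shows. Statements on the series, on what has been measured and on what is new or still open speak of the compounds shown alone.

compound 1 `COC(=O)C1=C(C)N=C(C)/C(=C(\O)OC)C1c1cc([N+](=O)[O-])ccc1Cl`: 30.2 nM
compound 2 `COC(=O)C1=C(C)N=C(C)/C(=C(\O)OC)C1c1cccc([N+](C)(C)C)c1`: 50100 nM

In a functional assay (muscle tissue) with Cavia porcellus as the target (on this read-out lower numbers stand for an effect already at smaller amounts and higher numbers for an effect only at larger amounts of compound), compound 2 has the higher of the two numbers at 50100 nM, and the gap to compound 1 at 30.2 nM lies beyond the scatter. The next compound to be measured is compound 3 `COC(=O)C1=C(C)N=C(C)/C(=C(\O)OC)C1c1cccc([N+](=O)[O-])c1`. Going from compound 2 to compound 3, the change is a group of 3 heavy atoms (1 nitrogen, 2 oxygen; no ring) in place of a group of 4 heavy atoms (3 carbon, 1 nitrogen; no ring), on an aromatic carbon, on an aromatic carbon, meta to a large group. Among the compounds with values here, no step between measured compounds differing in one place is available, so the expectation rests on a single reference point: compound 1 also carries a nitro group and gives 30.2 nM. A large fall in the number, well beyond the scatter, is expected, and the estimated step is a 2000-fold lower number from compound 2 to compound 3 (3.30 log units; beyond the scatter). The estimate for compound 3 is 25 nM, with an expected range of 5 nM to 120 nM.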

Compound 3, half-maximal effective concentration: 3.98 nM
Estimate against measurement, compound 3: 6.3-fold (0.80 log units) above; the measured number lies below the stated range.
By their numbers in this assay, from the lowest: compound 3; then compound 1; then compound 2.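

Working notes: in this assay the nitro group in place of the charged group, on the aromatic carbon meta to a large group, gives a 13000-fold lower number from compound 2 to compound 3 (4.10 log units; beyond the scatter), the first direct reading of this position, and shows that this one change on the shared core moves the number very strongly. Hydrogen in place of chloro gives a 7.6-fold lower number from compound 1 to compound 3 (0.88 log units; beyond the scatter), a modest step beside the first one, so a low number here does not depend on the chloro group. No measurement on hand accounts for either step.

The compounds shown do not separate the net charge of +1 from the other differences between the two leaving and entering groups. On these data alone, a tert-butyl or dimethylamino group at this place would bear on that, and whether fluoro or methyl in place of chloro also lowers the number remains open.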